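The source may report more compounds than this note shows. Statements on the series, on what has been measured and on what is new or still open speak of the compounds shown alone.

Notes on the series, in which only the group on a carbonyl carbon varies around a shared core. In an ADME assay on cells (Hepatocyte, Homo sapiens) for metabolic stability, with a stated time of 30 min (on this read-out higher numbers stand for a more stable compound and lower numbers for a less stable compound), compound 3 `CC(=O)OC1CCC(CN2CCN(c3cc(=O)c4cc(C(F)(F)F)cc([N+](=O)[O-])c4s3)CC2)CC1` gives 0%. Compound 2 `O=C(OC1CCC(CN2CCN(c3cc(=O)c4cc(C(F)(F)F)cc([N+](=O)[O-])c4s3)CC2)CC1)c1ccncc1` gives 1%, within the scatter of compound 3, as the step of a number 1 percentage points lower from compound 2 to compound 3 (within the scatter) shows. Compound 1 `O=C(OC1CCC(CN2CCN(c3cc(=O)c4cc(C(F)(F)F)cc([N+](=O)[O-])c4s3)CC2)CC1)c1ccccc1` gives 56.4% and stands well apart from both, with a number 56.4 percentage points lower from compound 1 to compound 3 (beyond the scatter) and a number 55.4 percentage points lower from compound 1 to compound 2 (beyond the scatter).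

The next change leads to compound 4 `O=C(OC1CCC(CN2CCN(c3cc(=O)c4cc(C(F)(F)F)cc([N+](=O)[O-])c4s3)CC2)CC1)c1ccc(C(F)(F)F)cc1`: 4-(trifluoromethyl)phenyl in place of methyl on a carbonyl carbon. In words, 4-(trifluoromethyl)phenyl stands in place of methyl on a carbonyl carbon. Among the compounds with values here, the closest precedent is the phenyl of compound 1, which makes a number 56.4 percentage points lower from compound 1 to compound 3 (beyond the scatter) the step that bears most directly, read in reverse. Compound 2 counsels caution, since its pyridin-4-yl also carries a six-membered aromatic ring, yet a number 1 percentage points lower from compound 2 to compound 3 (within the scatter) stays within the scatter. Within the data shown here, no measured pair tests a trifluoromethyl group on the phenyl ring of compound 1, so the data leave that contribution open.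

A large upward move in this assay is therefore expected, though somewhat smaller than the full gap and with wide uncertainty. The expected step is a number 42 percentage points higher from compound 3 to compound 4 (beyond the scatter). In this assay the estimate for compound 4 is 42%, with an expected range from 12% to 72%.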

Compound 4, percent of the compound remaining: 5.2%
Compound 4: middle estimate off by 36.8 percentage points, on the high side; the whole stated range lies above it.
By their numbers in this assay, from the lowest: compounds 3, 2 and 4 (each within the scatter of the next); then compound 1.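

In this assay a carbon-only aromatic ring on the carbonyl carbon proves not to be enough for a high number: a number 5.2 percentage points higher from compound 3 to compound 4 (within the scatter) and a number 4.2 percentage points higher from compound 2 to compound 4 (within the scatter), which places 4-(trifluoromethyl)phenyl with methyl and pyridin-4-yl and leaves compound 1 as the only one of the four standing apart. Within the data shown here, this is also the first measured change on the ring itself, and a number 51.2 percentage points lower from compound 1 to compound 4 (beyond the scatter) shows that trifluoromethyl in place of hydrogen on an aromatic carbon is enough to remove almost all of the gap that separates compound 1 from the others, so the read-out at this position depends on the substitution of the ring as well as on the ring's presence. Nothing available accounts for this loss.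

On these data alone, whether compound 1 is a lone high value or one of several remains open, as a fluorine, a methyl group, a methoxy group or an amine on its phenyl ring would be needed to tell. The read-out also does not show which part of these molecules is lost during the incubation.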